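Adding a Cyclopropyl Group to Compound 2

A few compounds are considered here, and "the series" means these few. Any claim that something is new, unique, unknown or untested is made for them only; others in the source may bear on it.

- compound 1 `C[C@H](Oc1ccc2ncc(/C=C/C(=O)O)c(C3CC3)c2c1)c1c(Cl)cccc1Cl` gives 3.7
- compound 2 `Cc1cc(O[C@@H](C)c2c(Cl)ccc(F)c2Cl)ccc1/C=C/C(=O)O` gives 3.2

Within the data shown here, both numbers come from one measurement, a physicochemical assay for lipophilicity, using the shake flask method (on this read-out lower numbers stand for lower lipophilicity and higher numbers for higher lipophilicity), and only two compounds have been measured so far. Of these two, compound 2 stands lowest with 3.2 on this scale, and its gap to compound 1 lies beyond the usual scatter.

Compound 3 `C[C@H](Oc1ccc(/C=C/C(=O)O)c(CC2CC2)c1)c1c(Cl)ccc(F)c1Cl` differs from compound 2 in one place (cyclopropyl in place of hydrogen on a saturated chain carbon bound to an aromatic carbon). The change is cyclopropyl in place of hydrogen on a saturated chain carbon bound to an aromatic carbon, which can also be read as methyl to cyclopropylmethyl.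

Among the measured compounds shown here, no measured pair shows this change, so the size of the step has to be judged from the structures alone. The entering group holds carbon only, with no hydrogen-bond donors or acceptors. An upward move beyond the scatter is expected, with an estimated step of a number 0.60 log units higher from compound 2 to compound 3 (beyond the scatter) in this assay on this scale. Compound 1 with 3.7 shows that a number of that height occurs in this small set. For compound 3 the estimate is 3.8, with an expected range of 3.4 to 4.2 in this measurement.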

Compound 3, distribution coefficient: 3.9
The estimate for compound 3 lay 0.10 log units below the measured number; the measured number falls inside the stated range.
By their numbers in this assay, from the lowest: compound 2; then compounds 1 and 3 (each within the scatter of the next).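

In this assay, among these compounds, cyclopropyl in place of hydrogen on a saturated chain carbon bound to an aromatic carbon gives a number 0.70 log units higher from compound 2 to compound 3 (beyond the scatter), and this is the first step in the set that can be read from two compounds differing in one place. The same difference can be read as methyl to cyclopropylmethyl, so it shows that adding a carbon-only ring at this place, with no hydrogen-bond donors or acceptors, moves this read-out upward in this one pair. No measurement at hand explains the size of this step, and a single pair cannot separate the effect of the ring from that of simply adding carbon.

From the compounds shown here alone, what stays open is how other groups at this same place would read on this scale, such as an ethyl group, a longer straight chain, a cyclobutyl ring, or a chain carrying an amine or a hydroxyl. One pair also leaves open whether the same change on a different core, such as the core of compound 1, would give a step of similar size.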